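Tert-butyl for isobutyl on the amine nitrogen

The source may hold more compounds than are shown below. What is called first, only, known or untested is meant among the compounds shown, and "the series" means these compounds.

In a functional assay on MCF7 cells (Homo sapiens) for antiproliferative activity (a higher number here means a weaker inhibitor, a lower number a stronger inhibitor), compound 1 (`CC(C)=CCc1cc(C(=O)Nc2cc3ccc(OCC4CCN(C)C4)c(C)c3oc2=O)ccc1O`) gives 1550 nM and compound 2 (`CC(C)=CCc1cc(C(=O)Nc2cc3ccc(OCCCNCC(C)C)c(C)c3oc2=O)ccc1O`) gives 1320 nM, so compound 2 stands level with compound 1. Compound 3 (`CC(C)=CCc1cc(C(=O)Nc2cc3ccc(OCCCNC(C)(C)C)c(C)c3oc2=O)ccc1O`) carries tert-butyl in place of isobutyl on an amine nitrogen. Among the measured compounds shown here, the only measured step, a 1.2-fold lower number from compound 1 to compound 2 (0.07 log units; within the scatter), replaced a larger part of the side chain and does not test this exchange directly, but it offers no sign of a large shift. The expected change in this assay is a 1.1-fold higher number from compound 2 to compound 3 (0.03 log units; within the scatter), so nothing beyond the scatter is anticipated. The estimated value for compound 3 is 1400 nM (expected range 700 nM to 2800 nM).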

Compound 3, half-maximal inhibitory concentration: 950 nM
For compound 3 the middle estimate is 1.5-fold (0.17 log units) above the measured one, and the stated range covers the measured number.
By their numbers in this assay, from the lowest: compounds 3, 2 and 1 (each within the scatter of the next).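

In this assay, the direct exchange on the amine nitrogen gives a 1.4-fold lower number from compound 2 to compound 3 (0.14 log units; within the scatter) and so shows that tert-butyl can replace isobutyl at this position without a shift beyond the scatter. The wider replacement of 1-methylpyrrolidin-3-yl gives a 1.6-fold lower number from compound 1 to compound 3 (0.21 log units; within the scatter) and also stays within the scatter, so all three side chains remain level. No measurement is available to explain these small differences. Open, from the compounds shown here alone, is whether a primary amine, a morpholine or a carboxylic acid in place of the substituted amine, or a longer chain, would move the number beyond the scatter.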